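The compounds below may be only part of what the source reports. "The series", "measured", "known", "first", "only" and "open" are said of these compounds alone.

Values so far in an ADME assay on microsomes from liver (Homo sapiens) for metabolic stability; a lower number here means slower removal, a higher number faster removal of the compound:
- compound 1 `O=C(N[C@H]1CN(S(=O)(=O)c2ccccc2)C[C@@H]1C(=O)N1C[C@H]2CCNC[C@H]21)c1cc(-c2ccccc2Cl)on1`: 7.3 mL.min-1.g-1
- compound 2 `CN(C(=O)[C@H]1CN(S(=O)(=O)c2ccccc2)C[C@@H]1NC(=O)c1cc(-c2ccccc2Cl)on1)[C@H]1CCCNC1`: 4.2 mL.min-1.g-1

With only these two numbers, compound 2 at 4.2 mL.min-1.g-1 stands within the scatter of compound 1, so neither value can be ranked above the other. The next structure is compound 3 `CN1CCC[C@H](NC(=O)[C@H]2CN(S(=O)(=O)c3ccccc3)C[C@@H]2NC(=O)c2cc(-c3ccccc3Cl)on2)C1`, which has the same atoms as compound 2, joined differently: a group of 8 heavy atoms (6 carbon, 2 nitrogen; one six-membered non-aromatic ring with 1 hetero atom) in place of a group of 8 heavy atoms (6 carbon, 2 nitrogen; one six-membered non-aromatic ring with 1 hetero atom), on a carbonyl carbon. The entering group is (1-methylpiperidin-3-yl)amino. Going by the values given here, one measured step bears on this place: a 1.7-fold lower number from compound 1 to compound 2 (0.24 log units; within the scatter). That step exchanged a different pair of groups on a carbonyl carbon and stayed within the scatter, so it offers only indirect guidance. No step beyond the scatter is expected in this assay, and the data support no firm direction. The expected step is a 1.2-fold higher number from compound 2 to compound 3 (0.08 log units; within the scatter). The estimated value for compound 3 is 5 mL.min-1.g-1, with an expected range of 2.5 mL.min-1.g-1 to 11 mL.min-1.g-1.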

Compound 3, intrinsic clearance in microsomes: 106 mL.min-1.g-1
Compound 3: the middle estimate sits 21-fold (1.33 log units) below what was measured; the measured number lies above the stated range.
By their numbers in this assay, from the lowest: compounds 2 and 1 (each within the scatter of the next); then compound 3.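

In this assay, this place on a carbonyl carbon proves sensitive to how the same atoms are joined: the entry of (1-methylpiperidin-3-yl)amino gives a 25-fold higher number from compound 2 to compound 3 (1.40 log units; beyond the scatter). The entering group also gives a 15-fold higher number from compound 1 to compound 3 (1.16 log units; beyond the scatter), whereas the exchange between the two earlier groups stayed within the scatter, so among these three compounds the same count of heavy atoms and the presence of one six-membered non-aromatic ring do not fix the number. Nothing available accounts for this jump.

Open, on these data alone, is whether the high number goes with the methyl on the piperidine ring or with the free amide hydrogen on the carbonyl carbon. A (piperidin-3-yl)amino group, or a (1-ethylpiperidin-3-yl)amino group, at this place would separate those two readings.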